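Amino Link Removed at the Carbonyl: Compound 3

The source may hold more compounds than are shown below. What is called first, only, known or untested is meant among the compounds shown, and "the series" means these compounds.

Compound 1 `COc1cc(Cl)cc(-c2nn(-c3cccc(NC(=O)Nc4ccc(Cl)c(Cl)c4)c3)cc2-c2ccncc2)c1`: 96%
Compound 2 `COc1cc(Cl)cc(-c2nn(-c3cccc(NC(=O)Nc4cccc(C(F)(F)F)c4)c3)cc2-c2ccncc2)c1`: 92%

In a functional assay on ACHN cells (Homo sapiens) for inhibition, read by sulforhodamine B assay, with a stated time of 48 h, tested at 0.1 uM (on this read-out higher numbers stand for a weaker effect at the one concentration tested and lower numbers for a stronger effect), compound 1 gives 96%. Among the measured compounds shown here, compound 2 gives 92% in this assay, and the only measured step, a number 4 percentage points lower from compound 1 to compound 2 (within the scatter), is within the scatter, so the two values stand together and neither can be called the stronger. Compound 3 `COc1cc(Cl)cc(-c2nn(-c3cccc(NC(=O)c4cccc(C(F)(F)F)c4)c3)cc2-c2ccncc2)c1` differs from compound 2 as follows: 3-(trifluoromethyl)phenyl in place of (3-(trifluoromethyl)phenyl)amino on a carbonyl carbon. For the measured compounds named here, no measured step touches the carbonyl carbon, so no step size can be read across from the data. Compound 3 is therefore expected to stay within the scatter of compound 2, with the step of a number 1 percentage points higher from compound 2 to compound 3 (within the scatter). The estimate for compound 3 in this assay is 93%, between 80% and 105%.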

Compound 3, a percentage reported as activity, at one concentration (the size of the read-out at that concentration, not a potency): 98%
The estimate for compound 3 lay 5 percentage points below the measured number, within the range that was stated.
By their numbers in this assay, from the lowest: compounds 2, 1 and 3 (each within the scatter of the next).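

In this assay, losing the amino link on the carbonyl carbon gives a number 6 percentage points higher from compound 2 to compound 3 (within the scatter), and the change from the (3,4-dichlorophenyl)amino group gives a number 2 percentage points higher from compound 1 to compound 3 (within the scatter). The earlier pair varied only the aryl group, whereas these steps show that at this one concentration the read-out does not separate a carbonyl carbon carrying the amino link from one carrying the aryl group directly. Nothing available bears on the cause of this result. On these data alone, it remains open whether a methylene link, as in a 3-(trifluoromethyl)benzyl group on the carbonyl carbon, would move the read-out beyond the scatter.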